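Trading the carbamoyl for a vinyl on the sulfur chain

This account rests on a few compounds, and the source may have more. Where it says the series, first, only, none or still open, it means among the compounds named here.

Three compounds share one core and differ only in the group carried on the chain attached to the sulfur. Compound 1 `CC(C)c1n[nH]c2c(NCc3ccc(-c4ccccn4)cc3)nc(SCC(N)=O)nc12`, measured in a functional assay on HT cells (Homo sapiens) for antiproliferative activity, read by fluorescence, with a stated time of 72 h (on this read-out higher numbers stand for weaker inhibition of growth and lower numbers for stronger inhibition of growth), gives 192 nM, the second highest of the three numbers. Compound 2 `CC(C)c1n[nH]c2c(NCc3ccc(-c4ccccn4)cc3)nc(SCCCN(C)C)nc12` gives 105 nM, and compound 3 `CC(C)c1n[nH]c2c(NCc3ccc(-c4ccccn4)cc3)nc(SCC(N)CN)nc12` gives 480 nM. The step of a 1.8-fold lower number from compound 1 to compound 2 (0.26 log units; within the scatter) stays within the scatter, whereas the step of a 2.5-fold higher number from compound 1 to compound 3 (0.40 log units; beyond the scatter) and the step of a 4.6-fold higher number from compound 2 to compound 3 (0.66 log units; beyond the scatter) are modest but real.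

Compound 4 `C=CCSc1nc(NCc2ccc(-c3ccccn3)cc2)c2[nH]nc(C(C)C)c2n1` has not been measured. It differs from compound 1 in one place: vinyl in place of carbamoyl on a saturated chain carbon bound to a sulfur. The two measured steps that start from compound 1 show that changing this group moves the growth-inhibiting concentration only modestly, in either direction. The expectation for compound 4 in this assay is therefore a number close to that of compound 1, with a small lean toward a higher number, expressed as a 1.4-fold higher number from compound 1 to compound 4 (0.13 log units; within the scatter). Compound 4 is estimated at 260 nM, within a range from 100 nM to 700 nM.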

Compound 4, concentration for 50% growth inhibition: 1010 nM
Estimate against measurement, compound 4: 3.9-fold (0.59 log units) below; measured number above the stated range.
By their numbers in this assay, from the lowest: compounds 2 and 1 (each within the scatter of the next); then compound 3; then compound 4.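

Going by these compounds alone, the allyl chain of compound 4 shows that this position tolerates less than the earlier compounds suggested: in this assay the change from carbamoyl to vinyl weakens growth inhibition clearly (a 5.3-fold higher number from compound 1 to compound 4 (0.72 log units; beyond the scatter)). The other two steps point the same way (a 2.1-fold higher number from compound 3 to compound 4 (0.32 log units; beyond the scatter); a 9.6-fold higher number from compound 2 to compound 4 (0.98 log units; beyond the scatter)), which makes compound 4 the weakest of the four, with every step to it beyond the scatter. The carbamoyl has one hydrogen-bond donor and one acceptor while the vinyl has neither, but nothing measured here explains the loss.

Still open, from the compounds shown here alone, is whether a saturated propyl chain would match the allyl chain of compound 4. A carboxylic acid or a longer chain ending in an amide might also bring the number back towards that of compound 1.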